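Adding a Methylsulfonyl Group to a Non-Toxic Core

The compounds below may be only part of what the source reports. "The series", "measured", "known", "first", "only" and "open" are said of these compounds alone.

Compound 1 `CSc1nc(N)c2ccn(COCCO)c2n1` and compound 2 `Nc1ncnc2c1ccn2COCCO` share the same core. In a functional assay on HFF cells (Homo sapiens) for cytotoxicity (on this read-out higher numbers stand for weaker inhibition and lower numbers for stronger inhibition), compound 1 gives only a limit of the assay, > 100000 nM. In this assay compound 2 likewise gives only a limit of the assay, > 100000 nM. The step that the two limits leave unreadable from compound 1 to compound 2 therefore has no readable size. Compound 2 thus stands at the limit of > 100000 nM in this assay, at which 2 of the 2 values shown sit. Compound 3 `CS(=O)(=O)c1nc(N)c2ccn(COCCO)c2n1` differs from compound 2 by methylsulfonyl in place of hydrogen on an aromatic carbon. Within the data shown here, no measured step offers a readable size, so the step of a number no higher from compound 2 to compound 3 (the limit leaves the size open) is expected to stay within the usual scatter. Compound 3 is accordingly estimated at 100000 nM, with a range from 40000 nM to 300000 nM.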

Compound 3, half-maximal inhibitory concentration: > 100000 nM
Compound 3 ended at the assay's limit; the forecaster's own chance of this, stated with the estimate: 85%; the middle value lies on the limit itself.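

No step can be read among compound 1, compound 2 and compound 3, since each gives only a limit: the limit of > 100000 nM in this assay, at which 3 of the 3 values shown sit. As far as these compounds go, whether methylsulfanyl, methylsulfonyl or hydrogen at that aromatic carbon makes any difference in this assay stays open.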